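Swapping an isobutyl for a phenoxy on a shared core

The compounds below may be only part of what the source reports. "The series", "measured", "known", "first", "only" and "open" are said of these compounds alone.

Measured so far:
- compound 1, `Cc1[nH]c(=O)n(C2CCCCC2)c1-c1ccccc1` — 47600 nM
- compound 2, `Cc1[nH]c(=O)n(C)c1-c1ccc(CC(C)C)cc1` — 7800 nM
- compound 3, `CCCCCCCCc1ccc(-c2c(C)[nH]c(=O)n2C)cc1` — 19400 nM

All three values come from a functional assay on brain (Rattus norvegicus, strain Wistar) for inhibition; a lower number here means a stronger inhibitor, a higher number a weaker inhibitor. Among them, compound 2 gives the lowest number at 7800 nM; compound 3 sits nearest, and compound 1 furthest from it. Going by the values given here, the one step measured within this set runs a 2.5-fold higher number from compound 2 to compound 3 (0.40 log units; beyond the scatter), a heptyl in place of an isopropyl on a saturated chain carbon bound to an aromatic carbon, so a longer chain at that position went hand in hand with a weaker inhibitor.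

Compound 4, `Cc1[nH]c(=O)n(C)c1-c1ccc(Oc2ccccc2)cc1`, is built from compound 2 by a different kind of change: phenoxy in place of isobutyl on an aromatic carbon. Here the outgoing group is a branched chain and the incoming one brings one six-membered aromatic ring of carbon only linked through an oxygen. Among the compounds with values here, no measured step in this set exchanges a chain for a ring at that position, so the step from compound 2 to compound 3 is only an indirect guide: it shows that changing the group on this aromatic carbon does move the number, by a modest amount. On that basis a modest shift toward a higher number is expected, as a 1.5-fold higher number from compound 2 to compound 4 (0.19 log units; within the scatter). Compound 4 is therefore estimated at 12000 nM, with a range from 4000 nM to 40000 nM.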

Compound 4, half-maximal inhibitory concentration: 8100 nM
Beside the measured number, compound 4's estimate is 1.5-fold (0.17 log units) above it; measured number inside the range.
By their numbers in this assay, from the lowest: compounds 2 and 4 (each within the scatter of the next); then compound 3; then compound 1.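

In this assay, exchanging the isobutyl for a phenoxy on this aromatic carbon gives a 1.0-fold higher number from compound 2 to compound 4 (0.02 log units; within the scatter), so the two compounds cannot be told apart. Going by these compounds alone, until now the only change measured here was the longer chain, a 2.5-fold higher number from compound 2 to compound 3 (0.40 log units; beyond the scatter), which left open whether any larger group would give a weaker inhibitor; compound 4 shows that this need not be so, since phenoxy brings 7 heavy atoms, one six-membered aromatic ring of carbon only and 1 hydrogen-bond acceptor where isobutyl had 4 heavy atoms and no ring, and the number still stays within the scatter. Nothing given here explains why these two quite different groups end up so close.

As far as these compounds go, it remains open how the number would respond to a plain phenyl, a benzyloxy, an amine or a carboxylic acid on this same aromatic carbon, which would help show which part of the phenoxy, the oxygen link or the ring, matters here, if either does. From the compounds shown here alone, it is also open whether phenoxy would give a similar result on the core of compound 1, which carries a cyclohexyl.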